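From 4-(trifluoromethyl)phenyl to 3-hydroxyphenyl on a shared core

The source may hold more compounds than are shown below. What is called first, only, known or untested is meant among the compounds shown, and "the series" means these compounds.

In a functional assay on MCF7 cells (Homo sapiens) for antiproliferative activity, read by MTT assay, with a stated time of 72 h (a lower number here means a stronger inhibitor, a higher number a weaker inhibitor), compound 1 `COc1ccc(-c2ccc3ncn(-c4cc(OC)c(OC)c(OC)c4)c3c2)cc1F` gives 520 nM and compound 2 `COc1cc(-n2cnc3ccc(-c4ccc(C(F)(F)F)cc4)cc32)cc(OC)c1OC` gives 760 nM. Among the measured compounds shown here, these two numbers lie within the scatter of each other, so compound 2 stands level with the only other measured compound. Compound 3 `COc1cc(-n2cnc3ccc(-c4cccc(O)c4)cc32)cc(OC)c1OC` keeps the core of compound 2 and carries 3-hydroxyphenyl in place of 4-(trifluoromethyl)phenyl on an aromatic carbon. For the measured compounds named here, one measured step bears on this exchange, at the same place on the core: a 1.5-fold higher number from compound 1 to compound 2 (0.16 log units; within the scatter). Going by the values given here, no measured compound yet carries 3-hydroxyphenyl, so this single step is weak guidance and the range must stay wide. No step beyond the scatter is therefore expected in this assay, and the estimated step is a 1.4-fold lower number from compound 2 to compound 3 (0.14 log units; within the scatter). For compound 3 the expected value is 550 nM, with an estimated range of 170 nM to 1800 nM.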

Compound 3, half-maximal inhibitory concentration: 350 nM
Beside the measured number, compound 3's estimate is 1.6-fold (0.20 log units) above it; the range from low to high includes it.
By their numbers in this assay, from the lowest: compounds 3, 1 and 2 (each within the scatter of the next, the first and the last beyond it).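

In this assay, among the compounds shown here, the exchange of 4-(trifluoromethyl)phenyl for 3-hydroxyphenyl gives a 2.2-fold lower number from compound 2 to compound 3 (0.34 log units; beyond the scatter) and so provides the first step at this position that passes the scatter, though only modestly. Measured against 3-fluoro-4-methoxyphenyl, the same group gives a 1.5-fold lower number from compound 1 to compound 3 (0.17 log units; within the scatter) and leaves those two compounds level, so the position accepts a group with one hydrogen-bond donor and one hydrogen-bond acceptor without loss, and the only separation seen is from the trifluoromethyl compound. No measurement at hand explains this difference.

Whether the hydroxyl itself accounts for the step stays open, as the compounds shown offer no plain phenyl group to compare with. Equally open, on these data alone, is how an amine or a carboxylic acid on that phenyl ring would read in this assay on the shared core.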